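A few compounds are considered here, and "the series" means these few. Any claim that something is new, unique, unknown or untested is made for them only; others in the source may bear on it.

In a functional assay on PC-3 cells (Homo sapiens) for antiproliferative activity, with a stated time of 48 h (a lower number here means a stronger inhibitor, a higher number a weaker inhibitor), compound 1 (`CCN(CC)c1ccc(-c2ccc(C#N)cc2)nn1`) gives > 25000 nM, which is a limit of the assay and not a number. Compound 2 (`CCN(CC)c1ccc(-c2ccc(C(=O)O)cc2)nn1`) gives > 25000 nM, which is likewise only a limit. Compound 2 therefore has no readable position, and the whole record so far consists of the limit of > 25000 nM in this assay, at which 2 of the 2 values shown sit. Among the compounds with values here, the one measured step, a step that the two limits leave unreadable from compound 1 to compound 2, has no readable size and points in neither direction.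

Compound 3 (`CCOC(=O)c1ccc(-c2ccc(N(CC)CC)nn2)cc1`) has ethyl in place of hydrogen on an oxygen next to a carbonyl group, so that carboxy becomes ethoxycarbonyl: ethyl in place of hydrogen on an oxygen next to a carbonyl group. Within the data shown here, no measured step covers this change, and the data give no size for it. The expectation can only start from compound 2, whose > 25000 nM is a limit, and it assumes little movement from there. The expected step is a number no higher from compound 2 to compound 3 (the limit leaves the size open). In this assay, the estimate for compound 3 is 25000 nM, with an expected range from 9000 nM to 40000 nM.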

Compound 3, half-maximal inhibitory concentration: 1000 nM
Beside the measured number, compound 3's estimate is 25-fold (1.40 log units) above it; the whole stated range lies above it.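

Within the data shown here, compound 3 is the first compound in this assay to give a number and not a limit, and it shows that this oxygen is a position where a small change can count: ethyl in place of hydrogen on an oxygen next to a carbonyl group gives an at least 25-fold lower number from compound 2 to compound 3 (1.39 log units; beyond the scatter). Set against the cyano compound, ethoxycarbonyl on the same aromatic carbon gives an at least 25-fold lower number from compound 1 to compound 3 (1.39 log units; beyond the scatter), while the step between cyano and carboxy still cannot be read. Both readable steps start from a limit, so they fix only a minimum size, and of the three groups shown at this place only ethoxycarbonyl comes off that limit: the limit of > 25000 nM in this assay, at which 2 of the 3 values shown sit.

The compounds shown leave open whether this value belongs to the ethyl group in particular or would hold for a methyl group, a longer chain such as butyl, or a benzyl group on the same oxygen. They also leave open whether an amide in place of the ester would stay near the value of compound 3 or fall back to the limit.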